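The source may hold more compounds than are shown below. What is called first, only, known or untested is meant among the compounds shown, and "the series" means these compounds.

Values in an in vivo ADME assay on the whole organism for pharmacokinetics, with Rattus norvegicus as the target; a higher number here means that more of the compound sits outside the plasma, a lower number that more of the compound stays in the plasma:
Compound 1 `O=C(Nc1cccnc1-c1ccsc1)N1CCN2C(=O)N([C@H]3C[C@@H]3c3ccccc3)C(=O)[C@@H]2C1`: 10 L/kg
Compound 2 `N#Cc1cc(Cl)c(NC(=O)N2CCN3C(=O)N([C@H]4C[C@@H]4c4ccccc4)C(=O)[C@@H]3C2)c(Cl)c1`: 0.5 L/kg
Compound 3 `O=C(Nc1cccc(Cl)c1Cl)N1CCN2C(=O)N([C@H]3C[C@@H]3c3ccccc3)C(=O)[C@@H]2C1`: not yet measured

Compound 2 holds the lower of the two numbers in this assay, at 0.5 L/kg, with compound 1 beyond the scatter from it. The next change is 2,3-dichlorophenyl in place of 2,6-dichloro-4-cyanophenyl on an amide-type nitrogen. Among the compounds with values here, the only measured step at this place is a 20-fold lower number from compound 1 to compound 2 (1.30 log units; beyond the scatter). Within the data shown here, it shows that the group here can move the number strongly, but it involves a different pair of groups, and no measured pair isolates the nitrile. A rise from compound 2 is therefore expected, though a smaller one than that large step. The expected step is a 3.0-fold higher number from compound 2 to compound 3 (0.48 log units; beyond the scatter). For compound 3 the estimated value is 1.5 L/kg, with an expected range of 0.6 L/kg to 5 L/kg.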

Compound 3, volume of distribution at steady state: 8 L/kg
For compound 3 the middle estimate is 5.3-fold (0.73 log units) below the measured one, outside the stated range (above it).
By their numbers in this assay, from the lowest: compound 2; then compounds 3 and 1 (each within the scatter of the next).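

In this assay the change on the amide-type nitrogen gives a 16-fold higher number from compound 2 to compound 3 (1.20 log units; beyond the scatter) and so shows that two chlorines on the phenyl ring do not by themselves go with the low number of compound 2. With a 1.3-fold lower number from compound 1 to compound 3 (0.10 log units; within the scatter) the 2,3-dichlorophenyl and 2-(thiophen-3-yl)pyridin-3-yl groups cannot be told apart here, which leaves compound 2 as the only one of the three set apart from the other two. Nothing at hand speaks to the origin of the large step.

The change from compound 2 to compound 3 alters the nitrile and the placing of the chlorines together, so the compounds shown do not say which of the two carries the step. Also open, from the compounds shown here alone, is how a carboxylic acid or an amine in place of the nitrile would read in this assay on the same dichlorophenyl group.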